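Swapping Isopropyl for a Longer Ester Chain

This account rests on a few compounds, and the source may have more. Where it says the series, first, only, none or still open, it means among the compounds named here.

Measured so far:
- compound 1 `CC(C)(C)OC(=O)CCN1CCc2c(sc(NC(=O)Nc3ccc(Cl)cc3)c2C(N)=O)C1` with 1100 nM
- compound 2 `CC(C)CN1CCc2c(sc(NC(=O)Nc3ccc(Cl)cc3)c2C(N)=O)C1` with 4510 nM

In a functional assay (strain AB) with Danio rerio as the target, read by microscopy, with a stated time of 1 h (on this read-out higher numbers stand for an effect only at larger amounts of compound and lower numbers for an effect already at smaller amounts), compound 2 holds the higher of the two numbers, at 4510 nM for now. Compound 3 `CC(C)(C)OC(=O)CCCN1CCc2c(sc(NC(=O)Nc3ccc(Cl)cc3)c2C(N)=O)C1` carries 2-(tert-butoxycarbonyl)ethyl in place of isopropyl on a saturated chain carbon bound to an amine nitrogen in a ring. Within the data shown here, one measured step bears on this change (a 4.1-fold higher number from compound 1 to compound 2 (0.61 log units; beyond the scatter)) and it is modest. That step replaced (tert-butoxycarbonyl)methyl with isopropyl, so the change to compound 3 brings the ester back on a longer chain. What that longer chain does has not been measured. A modest step towards a lower number is therefore expected in this assay and of similar size. The expected step is a 3.0-fold lower number from compound 2 to compound 3 (0.48 log units; beyond the scatter) on this reasoning. Compound 3 is estimated at 1500 nM with 500 nM to 4500 nM as the expected range.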

Compound 3, half-maximal effective concentration: 560 nM
Beside the measured number, compound 3's estimate is 2.7-fold (0.43 log units) above it; measured number inside the range.
By their numbers in this assay, from the lowest: compounds 3 and 1 (each within the scatter of the next); then compound 2.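

The result shows that on a saturated chain carbon bound to an amine nitrogen in a ring, 2-(tert-butoxycarbonyl)ethyl, like the shorter ester chain of compound 1, gives a lower number than isopropyl in this assay (an 8.1-fold lower number from compound 2 to compound 3 (0.91 log units; beyond the scatter)). Extending the ester chain makes no readable difference (a 2.0-fold lower number from compound 1 to compound 3 (0.29 log units; within the scatter)), so compound 1 and compound 3 cannot be told apart, while each stands clear of compound 2. Nothing available explains why the ester chains and isopropyl differ at this position.

Going by these compounds, whether the ester or simply the greater chain size matters remains open, and a carboxylic acid or a primary amide on the same chain would help separate the two. On these data alone, how far the chain can be extended is also open, since a longer chain carrying the same ester could hold the number or shift it.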